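This account rests on a few compounds, and the source may have more. Where it says the series, first, only, none or still open, it means among the compounds named here.

Measured in a functional assay on SK-BR-3 cells (Homo sapiens) for antiproliferative activity, read by MTT assay, with a stated time of 72 h; on this read-out lower numbers stand for stronger inhibition and higher numbers for weaker inhibition:

compound 1 `C/C=C1/[C@H](O[C@@H]2O[C@H](COC(C)=O)[C@@H](OC(C)=O)[C@H](OC(C)=O)[C@H]2OC(C)=O)OC=C(C(=O)OC)[C@H]1CC(=O)OCCC` — 6600 nM
compound 2 `C=C(C)CCOC(=O)C[C@@H]1C(C(=O)OC)=CO[C@@H](O[C@@H]2O[C@H](CO)[C@@H](O)[C@H](O)[C@H]2O)/C1=C/C` — > 15000 nM
compound 3 `C/C=C1/[C@H](O[C@@H]2O[C@H](COC(C)=O)[C@@H](OC(C)=O)[C@H](OC(C)=O)[C@H]2OC(C)=O)OC=C(C(=O)OC)[C@H]1CC(=O)OCCC1CCCCC1` — > 15000 nM.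

For compound 2 the value in this assay is a limit of the assay, not a number. Compound 4 `C/C=C1/[C@H](O[C@@H]2O[C@H](CO)[C@@H](O)[C@H](O)[C@H]2O)OC=C(C(=O)OC)[C@H]1CC(=O)OCCC` differs from compound 2 by methyl in place of 1-methylethenyl on a saturated chain carbon, two bonds along the chain from an oxygen next to a carbonyl group. Within the data shown here, the only measured step, an at least 2.2-fold higher number from compound 1 to compound 3 (0.35 log units; beyond the scatter), enlarged the group at this same place and weakened the inhibition; here the group shrinks, so any move is expected to run toward stronger inhibition. The starting point is a limit, however, and the limit of > 15000 nM in this assay, at which 2 of the 3 values shown sit, shows how often this assay reports only a limit rather than a number. Compound 4 is expected near 12000 nM, within 4000 nM to 30000 nM. The expected step is an at least 1.2-fold lower number from compound 2 to compound 4 (0.09 log units; that floor lies within the scatter).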

Compound 4, half-maximal inhibitory concentration: > 15000 nM
Compound 4 ended at the assay's limit (the forecaster's own chance of this, stated with the estimate: 50%); middle value at least 1.2-fold (0.09 log units) from the limit.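

Compound 2 and compound 4 both end at a limit of the assay, not at a number, so the step between them cannot be read: the limit of > 15000 nM in this assay, at which 3 of the 4 values shown sit.

On these data alone, whether methyl in place of 1-methylethenyl changes the inhibition at all, and by how much, stays open.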